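The compounds below may be only part of what the source reports. "The series", "measured", "known", "first", "only" and "open" are said of these compounds alone.

Of the compounds shown here, two sharing one core have been measured so far in a functional assay on OVCAR-3 cells (Homo sapiens) for inhibition, read by MTT assay, with a stated time of 24 h (on this read-out lower numbers stand for stronger inhibition and higher numbers for weaker inhibition), on these cells. Compound 1 `CC1(C)[C@H]2CC[C@]1(C)N(Cc1cn(-c3ccc(C#N)cc3)nn1)C(=O)C2` gives 380 nM there, and compound 2 `CC1(C)[C@H]2CC[C@]1(C)N(Cc1cn(-c3ccccc3F)nn1)C(=O)C2` gives 300 nM there. These two numbers lie within the usual scatter of each other, so compound 2 stands level with compound 1 and no ranking can be drawn between them. Compound 3 `CC1(C)[C@H]2CC[C@]1(C)N(Cc1cn(-c3ccc(Br)cc3)nn1)C(=O)C2` keeps the same core and differs from compound 2 at one place, with 4-bromophenyl in place of 2-fluorophenyl on an aromatic nitrogen. Going by the values given here, the only measured step at this place, 2-fluorophenyl in place of 4-cyanophenyl, is a 1.3-fold lower number from compound 1 to compound 2 (0.10 log units; within the scatter) and it is the sole guide here. Among the compounds with values here, on that single step, no change beyond the scatter is expected in this assay in either direction, although no compound carrying bromine has yet been measured. The expected move is small, an estimated 1.2-fold higher number from compound 2 to compound 3 (0.07 log units; within the scatter) at most in the sense of a working guess. Compound 3 is estimated at 350 nM and expected to fall between 150 nM and 800 nM.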

Compound 3, half-maximal inhibitory concentration: 140 nM
The estimate for compound 3 lay 2.5-fold (0.40 log units) above the measured number; the measured number lies below the stated range.
By their numbers in this assay, from the lowest: compound 3; then compounds 2 and 1 (each within the scatter of the next).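

The aryl group on the aromatic nitrogen turns out to matter in this assay, since the change to 4-bromophenyl gives steps beyond the scatter, though modest ones, whereas the earlier swap between 2-fluorophenyl and 4-cyanophenyl did not: a 2.1-fold lower number from compound 2 to compound 3 (0.33 log units; beyond the scatter), and a 2.7-fold lower number from compound 1 to compound 3 (0.43 log units; beyond the scatter). The second step is the easier to read, as bromo replaces cyano on the same aromatic carbon, so the identity of that one group alters the number, and compound 3 now stands alone as the most potent of the three on these cells. The first step changes both the halogen and where it sits on the phenyl ring, so it cannot show which of the two matters, and nothing shown here explains either step.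

A 2-bromophenyl or 4-fluorophenyl group would separate the halogen from its place on the ring, and so would settle what the step from 2-fluorophenyl leaves mixed. On these data alone, whether the trend extends to 4-chlorophenyl, 4-iodophenyl, 4-methoxyphenyl or plain phenyl also stays open.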